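From Trifluoromethyl to Fluoro: A Step from Compound 1

The compounds below may be only part of what the source reports. "The series", "measured", "known", "first", "only" and "open" are said of these compounds alone.

Compound 1 `Nc1scc(CN2CCN(c3cccc(C(F)(F)F)c3)CC2)c1C(=O)c1ccc(Cl)cc1` was tested in an assay on CHO cells for displacement of a labelled ligand from adenosine receptor A1 (Homo sapiens), read by scintillation counting, with a stated time of 120 min, tested at 10 uM (on this read-out higher numbers stand for more inhibition at the one concentration tested (going by the name of the read-out) and lower numbers for less inhibition), and gave 0%. Compound 2 `Nc1scc(CN2CCC(c3ccc(Cl)cc3)CC2)c1C(=O)c1ccc(Cl)cc1` gave 0% in this assay, and compound 3 `Nc1scc(CN2CCN(c3c(F)cccc3F)CC2)c1C(=O)c1cccc(C(F)(F)F)c1` gave 0%. On these numbers compound 1 stands level with compound 2 and compound 3 at the digits shown, all three within the usual scatter, so none of them separates from the others.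

Compound 4 `Nc1scc(CN2CCN(c3cccc(F)c3)CC2)c1C(=O)c1ccc(Cl)cc1` has not been measured. It differs from compound 1 by fluoro in place of trifluoromethyl on an aromatic carbon. With compounds 1, 2 and 3 all at the same reading, nothing in the data points to a change in either direction for this substitution. The step of no change at the digits printed from compound 1 to compound 4 (within the scatter) is therefore expected to be none beyond the scatter. Compound 4 is estimated at 0%, with a range from 0% to 10%.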

Compound 4, a percentage reported as inhibition, at one concentration (the size of the read-out at that concentration, not a potency): 1%
Compound 4: middle estimate off by 1 percentage points, on the low side; measured number inside the range.
By their numbers in this assay, from the lowest: compounds 1, 2, 3 and 4 (each within the scatter of the next).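

In this assay, among these compounds, the change from 3-(trifluoromethyl)phenyl to 3-fluorophenyl gives a number 1 percentage points higher from compound 1 to compound 4 (within the scatter), the first comparison here of two compounds that differ in one place. At this position on the aromatic ring, exchanging trifluoromethyl for fluoro therefore moves the reading by no more than the scatter, with both compounds at the low end of the read-out. No accompanying data explain this result. Going by these compounds, whether an amine or a carboxylic acid at this position would give a reading beyond the scatter remains open.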